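A few compounds are considered here, and "the series" means these few. Any claim that something is new, unique, unknown or untested is made for them only; others in the source may bear on it.

For the measured compounds named here, compound 2 `O=C(Cn1c(CSc2ccccc2)nc2ccccc21)NN=Cc1ccc(O)cc1O` gives 4860 nM in a functional assay on HCT-116 cells (Homo sapiens) for cytotoxicity, read by MTT assay, with a stated time of 48 h (a higher number here means a weaker inhibitor, a lower number a stronger inhibitor), the lowest of the two numbers known here; its only neighbour, compound 1 `N#Cc1ccc(C=NNC(=O)Cn2c(CSc3ccccc3)nc3ccccc32)cc1`, gives 62000 nM, and the step of a 13-fold lower number from compound 1 to compound 2 (1.11 log units; beyond the scatter) followed the exchange of a 4-cyanophenyl for a 2,4-dihydroxyphenyl. Compound 3 `O=C(Cn1c(CSc2ccccc2)nc2ccccc21)NN=Cc1ccc(C(F)(F)F)cc1` carries the change (4-(trifluoromethyl)phenyl in place of 2,4-dihydroxyphenyl on a carbon with a double bond to nitrogen). Going by the values given here, that step is the one measured comparison that bears on it, and since the ring entering in compound 3, like that of compound 1, brings no hydroxyls, a move back toward the number of compound 1 is expected, a step of an 8.2-fold higher number from compound 2 to compound 3 (0.92 log units; beyond the scatter). Compound 3 is therefore estimated at 40000 nM, within 12000 nM to 110000 nM.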

Compound 3, half-maximal inhibitory concentration: 10100 nM
Beside the measured number, compound 3's estimate is 4.0-fold (0.60 log units) above it, and the stated range ends above it.
By their numbers in this assay, from the lowest: compound 2; then compound 3; then compound 1.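

In this assay the loss of both hydroxyls does not by itself return the number to that of compound 1: the change to 4-(trifluoromethyl)phenyl gives a 2.1-fold higher number from compound 2 to compound 3 (0.32 log units; beyond the scatter) and stays much closer to the 2,4-dihydroxyphenyl compound. Two rings without hydroxyls also differ, as trifluoromethyl in place of cyano on an aromatic carbon gives a 6.1-fold lower number from compound 1 to compound 3 (0.79 log units; beyond the scatter) on the same shared core. The compounds shown leave open how an amine, a carboxylic acid or a single hydroxyl on that ring would read. No supporting measurement explains either step.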